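A few compounds are considered here, and "the series" means these few. Any claim that something is new, unique, unknown or untested is made for them only; others in the source may bear on it.

Measured compounds in this study:
compound 1 `COc1ccc(OC)c(/C=N/NC(=O)Nc2ccc(Oc3ccnc(-c4nncn4CCN(C)C)c3)c(F)c2)c1`, giving 2930 nM
compound 2 `CN(C)CCn1cnnc1-c1cc(Oc2ccc(NC(=O)N/N=C/c3cccc(Br)c3)cc2F)ccn1`, giving 520 nM
compound 3 `CN(C)CCn1cnnc1-c1cc(Oc2ccc(NC(=O)N/N=C/c3ccc(F)cc3)cc2F)ccn1`, giving 1980 nM

All three were tested in a functional assay on NCI-H460 cells (Homo sapiens) for cytotoxicity, read by MTT assay, with a stated time of 72 h; a higher number here means a weaker inhibitor, a lower number a stronger inhibitor. Compound 1 shows the highest number of the three. Its nearest neighbour is compound 3, and the step of a 1.5-fold lower number from compound 1 to compound 3 (0.17 log units; within the scatter) is within the scatter. Its furthest neighbour is compound 2, and the step of a 5.6-fold lower number from compound 1 to compound 2 (0.75 log units; beyond the scatter) is modest but beyond the scatter. Between the two halogen-bearing analogues the step of a 3.8-fold higher number from compound 2 to compound 3 (0.58 log units; beyond the scatter) is also modest and beyond the scatter.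

Compound 4 `COc1ccc(/C=N/NC(=O)Nc2ccc(Oc3ccnc(-c4nncn4CCN(C)C)c3)c(F)c2)c(OC)c1` has not yet been measured. It differs from compound 1 in one place: 2,4-dimethoxyphenyl in place of 2,5-dimethoxyphenyl on a carbon with a double bond to nitrogen. Both measured steps swap the whole group on the carbon with a double bond to nitrogen, whereas here the two groups share the same atoms, joined differently, so neither step addresses this change directly. One swap moved the number well beyond the scatter, the other did not. With no closer comparison available, the step of a 1.2-fold lower number from compound 1 to compound 4 (0.07 log units; within the scatter) is expected to fall within the scatter, in no firm direction. Compound 4 is therefore estimated at 2500 nM, with a range from 900 nM to 7000 nM.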

Compound 4, half-maximal inhibitory concentration: 1570 nM
The estimate for compound 4 lay 1.6-fold (0.20 log units) above the measured number; measured number inside the range.
By their numbers in this assay, from the lowest: compound 2; then compounds 4, 3 and 1 (each within the scatter of the next).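

Placing 2,4-dimethoxyphenyl in place of 2,5-dimethoxyphenyl on a carbon with a double bond to nitrogen gives a 1.9-fold lower number from compound 1 to compound 4 (0.27 log units; within the scatter), so in this assay these two groups, made of the same atoms joined differently, cannot be told apart. Compound 4 also cannot be told apart from the 4-fluorophenyl analogue, with a 1.3-fold lower number from compound 3 to compound 4 (0.10 log units; within the scatter), whereas the 3-bromophenyl analogue stays clear of it, with a 3.0-fold higher number from compound 2 to compound 4 (0.48 log units; beyond the scatter), which leaves compound 2 as the most potent of the four, its steps to the other three all printed as beyond the scatter, and the three others as a group that these data do not separate. No supporting information is available that would account for the standing of compound 2 or for the closeness of the others.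

The compounds shown leave open whether the separation of compound 2 belongs to the bromine itself or to its place on the phenyl group, a question that an unsubstituted phenyl or a chlorophenyl group on the same carbon would bear on. They also leave open whether a single methoxy group on that phenyl would read like the two dimethoxyphenyl compounds.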